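Cytotoxicity notes: methyl on the core of compound 2

The compounds below may be only part of what the source reports. "The series", "measured", "known", "first", "only" and "open" are said of these compounds alone.

The series is assessed in an ADME assay on Huh-7 cells (Homo sapiens) for cytotoxicity; on this read-out higher numbers stand for lower toxicity in this test and lower numbers for higher toxicity in this test. Compound 1 `NC(=S)Nc1cccc(OCCCCCNC(=S)Nc2ccc(Cl)cc2)c1` gives only a limit in this assay, > 50000 nM. Compound 2 `NC(=S)Nc1cccc(OCCCCCNC(=S)Nc2cccc3ccccc23)c1` likewise gives only a limit, > 50000 nM. Compound 3 `Cc1c(NC(N)=S)cccc1OCCCCCNC(=S)Nc1cccc2ccccc12` also gives only a limit, > 50000 nM. Compound 2 thus stands where its neighbours stand, at a limit with no number behind it, and both the step that the two limits leave unreadable from compound 1 to compound 2 and the step that the two limits leave unreadable from compound 2 to compound 3 stay unreadable because the limit of > 50000 nM in this assay, at which 3 of the 3 values shown sit, covers every value seen.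

Compound 4 `Cc1ccc(OCCCCCNC(=S)Nc2cccc3ccccc23)cc1NC(N)=S` differs from compound 2 by methyl in place of hydrogen on an aromatic carbon. The two measured steps bear on this change only as single substitutions on the shared core, and neither yielded a size. Going by the values given here, with the sole evidence being (the limit of > 50000 nM in this assay, at which 3 of the 3 values shown sit), no step in this assay beyond the scatter can be foreseen in either direction, nor any size at all. Compound 4 is therefore expected to remain at the same limit, with an estimated step that the limit leaves unreadable from compound 2 to compound 4. For compound 4 the estimated value in this assay is 80000 nM, within a range from 40000 nM to 200000 nM.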

Compound 4, half-maximal cytotoxic concentration: > 50000 nM
Compound 4 was reported as a limit (the forecaster's own chance of this, stated with the estimate: 85%); the middle value lies beyond the limit too.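

No new step can be read between compound 2 and compound 4, because both remain at a limit, as do compounds 1 and 3: the limit of > 50000 nM in this assay, at which 4 of the 4 values shown sit. The compounds shown leave open whether any change on the shared core, including methyl in place of hydrogen, shifts the half-maximal cytotoxic concentration, and by how much.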